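The source may report more compounds than this note shows. Statements on the series, on what has been measured and on what is new or still open speak of the compounds shown alone.

Of the compounds shown here, three have been measured in a functional assay on DU-145 cells (Homo sapiens) for cytotoxicity, read by MTT assay; on this read-out higher numbers stand for weaker inhibition and lower numbers for stronger inhibition. Compound 1 `CC(O)(CSc1ccc(Cl)cc1)c1nc(-c2ccc(Cl)cc2)no1` gives 14500 nM, compound 2 `CC(O)(CSc1ccc(Br)cc1)c1nc(-c2ccc([N+](=O)[O-])c(C(F)(F)F)c2)no1` gives 1600 nM, and compound 3 `CC(O)(CSc1ccccc1)c1nc(-c2ccc(F)c(Cl)c2)no1` gives 5500 nM. Among these three numbers compound 2 stands lowest; its nearest neighbour is compound 3, whose number is higher by a gap beyond the scatter, and the furthest is compound 1, higher still. No two of the measured compounds differ in only one place, so no single-change step can be read from them. Between compound 2 and each of the others there are several differences at once.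

Compound 4 `CC(O)(CSc1ccc(F)cc1)c1nc(-c2ccc([N+](=O)[O-])c(C(F)(F)F)c2)no1` has not yet been measured in this assay. It differs from compound 2 in one place: fluoro in place of bromo on an aromatic carbon. Nothing changes in ring count, hydrogen-bond donors or acceptors, or net charge.

Going by the values given here, with no measured step of this kind among the three compounds, the expectation rests on compound 2 at 1600 nM alone. Compound 4 is expected to show a small step in this assay, a 1.6-fold higher number from compound 2 to compound 4 (0.19 log units; within the scatter), towards a somewhat higher number, possibly within the scatter. The estimate for compound 4 is 2500 nM, in the range 1000 nM to 6500 nM.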

Compound 4, half-maximal inhibitory concentration: 5100 nM
Beside the measured number, compound 4's estimate is 2.0-fold (0.31 log units) below it; the measured number falls inside the stated range.
By their numbers in this assay, from the lowest: compound 2; then compounds 4 and 3 (each within the scatter of the next); then compound 1.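

In this assay, going by these compounds alone, the change from 4-bromophenyl to 4-fluorophenyl gives a 3.2-fold higher number from compound 2 to compound 4 (0.50 log units; beyond the scatter), and this is the first single-change step that can be read. The earlier compounds shown here differed in several places at once, so they could not isolate this position; here, with the rest of the molecule held fixed, the aromatic carbon para to a large group proves sensitive to which halogen it carries, with bromo going with the lower number and fluoro with the higher one. The step is modest but beyond the scatter, so the two halogens cannot be treated as interchangeable at this position, and no measurement at hand explains the difference.

Going by these compounds, this rests on a single pair, so it remains open whether the same step would appear with a different aryl group at the other end of the molecule, or whether it belongs to this particular partner alone. On these data alone, it also remains open where chloro or an unsubstituted phenyl would fall with the partner kept constant, and how a methoxy group or an amine at this position would read.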